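The source may report more compounds than this note shows. Statements on the series, on what has been measured and on what is new or still open speak of the compounds shown alone.

Three compounds were measured in an assay on CHO cells for displacement of a labelled ligand from adenosine receptor A3 (Homo sapiens), with a stated time of 60 min, tested at 10 uM; on this read-out higher numbers stand for more inhibition at the one concentration tested (going by the name of the read-out) and lower numbers for less inhibition:

Compound 1, `O[C@@H]1[C@H](O)CS[C@H]1Cn1cnc2c(NCc3cccc(Br)c3)nc(Cl)nc21`, gives 21%.
Compound 2, `O[C@@H]1[C@H](O)CS[C@H]1Cn1cnc2c(NCc3cccc(I)c3)nc(Cl)nc21`, gives 10%.
Compound 3, `O[C@@H]1[C@H](O)CS[C@H]1Cn1cnc2c(NCc3cccc(Br)c3)ncnc21`, gives 6.1%.

Compound 1 and compound 2 share a core and differ in one place: iodo in place of bromo on an aromatic carbon. This change made a step of a number 11 percentage points lower from compound 1 to compound 2 (beyond the scatter). Compound 3 carries a different core; how it differs from compound 1 is hydrogen in place of chloro on an aromatic carbon, and that change made a step of a number 14.9 percentage points lower from compound 1 to compound 3 (beyond the scatter). Compound 3 has the lowest of the three numbers, although its distance from compound 2 is within the scatter.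

Compound 4, `O[C@@H]1[C@H](O)CS[C@H]1Cn1cnc2c(NCc3cccc(I)c3)ncnc21`, is not yet measured. It differs from compound 3 by iodo in place of bromo on an aromatic carbon, the same change that turned compound 1 into compound 2, made at the same kind of place. That earlier step lowered the number, but compound 3 already sits near the bottom of this read-out, so there is little room left to fall. The expected step is a number 4.1 percentage points lower from compound 3 to compound 4 (within the scatter), resting on the earlier step of a number 11 percentage points lower from compound 1 to compound 2 (beyond the scatter) and on the low value of compound 3. Compound 4 is therefore expected to give about 2%, roughly between -8% and 10%.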

Compound 4, a percentage reported as inhibition, at one concentration (the size of the read-out at that concentration, not a potency): 13.9%
Beside the measured number, compound 4's estimate is 11.9 percentage points below it; measured number outside the range, above it.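

In this assay, iodo in place of bromo does not carry over from the core of compound 1 to the core of compound 3: the new step is a number 7.8 percentage points higher from compound 3 to compound 4 (within the scatter), and it does not match the earlier one: the same change on two cores in this assay, a number 11 percentage points lower (beyond the scatter) from compound 1 to compound 2 and a number 7.8 percentage points higher (within the scatter) from compound 3 to compound 4, 18.8 percentage points apart, beyond the scatter of two such steps

Hydrogen in place of chloro likewise fails to repeat once iodo replaces bromo, with the new step being a number 3.9 percentage points higher from compound 2 to compound 4 (within the scatter), so in these four compounds the result of one change depends on what stands at the other place: the same change on two cores in this assay, a number 14.9 percentage points lower (beyond the scatter) from compound 1 to compound 3 and a number 3.9 percentage points higher (within the scatter) from compound 2 to compound 4, 18.8 percentage points apart, beyond the scatter of two such steps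

This rests on a single set of four compounds read at one concentration, so it does not show why the steps differ, how either change would behave on other compounds of the series, or how potency would compare.

Still open, as far as these compounds go, is what a methoxy group or a nitrile would do in place of bromo or iodo on the aromatic ring. Also open, from the compounds shown here alone, is what an amine or a longer chain would do in place of the chloro.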